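The compounds below may be only part of what the source reports. "The series", "measured", "known", "first", "only" and "open" are said of these compounds alone.

Measured compounds

Compound 1 `CC[C@H](C)[C@H](NC(=O)c1cccc(Cn2ccnc2)c1)C(=O)Nc1nccs1`, 17%
Compound 2 `CCCCS(=O)(=O)NC(=O)[C@@H](NC(=O)c1cccc(Cn2ccnc2)c1)[C@@H](C)CC`, "not determined" (no result reported)

Notes. In an assay on HEK293 cells for displacement of a labelled ligand from Type-2 angiotensin II receptor (Homo sapiens), tested at 10 uM (a lower number here means a weaker effect, a higher number a stronger effect of the compound at the concentration tested), compound 1 gives 17%. For compound 2 the entry in this assay is "not determined" (no result reported), so compound 2 cannot be placed on the measured scale; the only anchor in the series is the modest read-out of compound 1.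

Compound 3 `CC[C@H](C)[C@H](NC(=O)c1cccc(Cn2ccnc2)c1)C(N)=O` differs from compound 2 as follows: hydrogen in place of butylsulfonyl on an amide-type nitrogen. With no measured step in this assay between any two compounds, the size of this step cannot be read off; as a working assumption, the change from compound 2 to compound 3 is expected to leave the read-out in this assay in the weak region already shown by compound 1, with no step beyond the usual scatter to be relied on in either direction.

For compound 3 the expected value in this assay is 12%, estimated to lie between 0% and 30%.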

Compound 3, a percentage reported as inhibition, at one concentration (the size of the read-out at that concentration, not a potency): "not active" (no number reported)
The entry for compound 3 holds no number; there is nothing to compare the estimate with.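

Neither compound 2 nor compound 3 has a numerical entry in this assay, so no step can be read between them. No supporting evidence bears on this result. The compounds shown leave open whether exchanging butylsulfonyl for hydrogen on the amide-type nitrogen changes the read-out.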